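The source may report more compounds than this note shows. Statements on the series, on what has been measured and on what is new or still open speak of the compounds shown alone.

In a physicochemical assay for solubility (a lower number here means a less soluble compound, a higher number a more soluble compound), the background to this step is thin. Compound 1 (`CS(=O)(=O)c1ccc(-n2nc(C(F)F)c(C#N)c2-c2ccccc2)nc1`) gives "not determined" (no result reported), and compound 3 (`CC(C)COc1cc(C(F)(F)F)nn1-c1ccc(S(C)(=O)=O)cc1`) gives "not determined" (no result reported), so compound 3 has no number of its own. Among the measured compounds shown here, the only figure comes from compound 2 (`CC(C)COc1cc(C(F)(F)F)nn1-c1ccc(S(C)(=O)=O)cn1`), which gives 50 ug/mL. Compound 4 (`CS(=O)(=O)c1ccc(-n2nc(C(F)(F)F)cc2OCC2CCC2)cc1`) carries a single change: cyclobutyl in place of isopropyl on a saturated chain carbon bound to an oxygen on an aromatic ring, with cyclobutyl in place of isopropyl on a saturated chain carbon bound to an oxygen on an aromatic ring. For the measured compounds named here, no measured step shows what this change does, so only a small downward step in this assay, hardly beyond the usual scatter, is expected. The sole anchor for that expectation is compound 2 at 50 ug/mL. Compound 4 is expected at about 15 ug/mL, within an estimated range of 3 ug/mL to 60 ug/mL.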

Compound 4, solubility: 25 ug/mL
Compound 4: middle estimate off by 1.7-fold (0.22 log units), on the low side; measured number inside the range.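

In this assay, among the compounds shown here, compound 3 has no single number, so no step to compound 4 can be read. From the compounds shown here alone, what the change from isobutyl to cyclobutylmethyl does to solubility stays open, and no supporting evidence bears on this result.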